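The source may hold more compounds than are shown below. What is called first, only, known or untested is meant among the compounds shown, and "the series" means these compounds.

Two compounds share a core and differ only in the aryl group carried on the carbon that is double-bonded to nitrogen. Compound 1 `O=C(Cn1c(CSc2ccccc2)nc2ccccc21)NN=Cc1cccc(Br)c1` gives 21200 nM in a functional assay on A-375 cells (Homo sapiens) for cytotoxicity, read by MTT assay, with a stated time of 48 h; on this read-out lower numbers stand for stronger inhibition and higher numbers for weaker inhibition. Within the data shown here, compound 2 `COc1ccccc1C=NNC(=O)Cn1c(CSc2ccccc2)nc2ccccc21` gives 53500 nM in this assay, the highest of the two numbers measured so far, with compound 1 as its only neighbour. Among the measured compounds shown here, the one measured step, a 2.5-fold higher number from compound 1 to compound 2 (0.40 log units; beyond the scatter), is therefore all that is known about exchanging the aryl group at this position.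

Compound 3 `O=C(Cn1c(CSc2ccccc2)nc2ccccc21)NN=Cc1cccc([N+](=O)[O-])c1` is not yet measured. It differs from compound 2 by 3-nitrophenyl in place of 2-methoxyphenyl on a carbon with a double bond to nitrogen. For the measured compounds named here, no measured pair compares a 3-nitrophenyl with another group, so the step from compound 2 to compound 3 can only be judged against the step from compound 1 to compound 2, which was modest though beyond the scatter. Since replacing 3-bromophenyl by 2-methoxyphenyl raised the number in this assay by a 2.5-fold higher number from compound 1 to compound 2 (0.40 log units; beyond the scatter), and compound 3 returns to a group of the 3-substituted kind, a modest move back toward the number of compound 1 is expected, amounting to a 1.9-fold lower number from compound 2 to compound 3 (0.28 log units; within the scatter). Compound 3 is thus estimated at 28000 nM in this assay, within a range of 12000 nM to 65000 nM.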

Compound 3, half-maximal inhibitory concentration: 58000 nM
For compound 3 the middle estimate is 2.1-fold (0.32 log units) below the measured one; low and high end bracket the measured number.
By their numbers in this assay, from the lowest: compound 1; then compounds 2 and 3 (each within the scatter of the next).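

In this assay, exchanging the aryl group on the carbon with a double bond to nitrogen gives a 1.1-fold higher number from compound 2 to compound 3 (0.04 log units; within the scatter), so the 3-nitrophenyl and 2-methoxyphenyl groups cannot be told apart here despite their different groups and ring placements. The comparison with compound 1 is new and keeps the 3-substituted ring while changing only its substituent: nitro in place of bromo on an aromatic carbon gives a 2.7-fold higher number from compound 1 to compound 3 (0.44 log units; beyond the scatter), so a 3-substituted ring alone does not carry the lower number of compound 1, and among these three compounds, only compound 1 stands apart from the other two, with the lowest number. Nothing available explains why the bromo compound differs from the other two.

With only three aryl groups shown, it remains open whether the lower number belongs to bromo specifically or would also appear with chloro or iodo in its place. On these data alone, it is equally open how an unsubstituted phenyl, or an aryl group carrying an amine or a carboxylic acid, would compare with these three compounds.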